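Replacing cyclopropyl by 3-fluorophenyl on the chain carbon

This account rests on a few compounds, and the source may have more. Where it says the series, first, only, none or still open, it means among the compounds named here.

Compound 3 `O=C(C1CC1)N1CCN(Cc2nc3ccccc3n2CC2CC2)CC1` is measured in an assay on isolated protein for inhibition of aldehyde dehydrogenase 1A1 (Homo sapiens), read by spectrophotometry, tested at 10 uM (a higher number here means more inhibition at the concentration tested (going by the name of the read-out), a lower number less inhibition), at 21.2%. Among the three measured numbers it stands second highest: compound 1 `CCn1c(CN2CCN(C(=O)C3CC3)CC2)nc2ccccc21` gives 20.8%, and compound 2 `CC(C)CCn1c(CN2CCN(C(=O)C3CC3)CC2)nc2ccccc21` gives 70%. The step of a number 0.4 percentage points higher from compound 1 to compound 3 (within the scatter) lies within the scatter, whereas a number 48.8 percentage points lower from compound 2 to compound 3 (beyond the scatter) is large. Compound 4 `O=C(C1CC1)N1CCN(Cc2nc3ccccc3n2Cc2cccc(F)c2)CC1` differs from compound 3 by 3-fluorophenyl in place of cyclopropyl on a saturated chain carbon bound to an aromatic nitrogen. Going by the values given here, the only measured step at this place that moves the number is the one from compound 2 to compound 3, where the group with more heavy atoms on the saturated chain carbon goes with the higher reading; 3-fluorophenyl likewise carries more heavy atoms than cyclopropyl. An increase is therefore expected, of uncertain size, as the expected step of a number 28.8 percentage points higher from compound 3 to compound 4 (beyond the scatter). Compound 4 is estimated at 50%, within 22% to 78%.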

Compound 4, a percentage reported as inhibition, at one concentration (the size of the read-out at that concentration, not a potency): 27.2%
Estimate against measurement, compound 4: 22.8 percentage points above; low and high end bracket the measured number.
By their numbers in this assay, from the lowest: compounds 1, 3 and 4 (each within the scatter of the next); then compound 2.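

In this assay, 3-fluorophenyl on a saturated chain carbon bound to an aromatic nitrogen gives a number 6 percentage points higher from compound 3 to compound 4 (within the scatter) and a number 6.4 percentage points higher from compound 1 to compound 4 (within the scatter), so the larger heavy-atom count of this aromatic ring does not by itself go with a high reading. Isobutyl alone stands apart among the groups shown, with a number 42.8 percentage points lower from compound 2 to compound 4 (beyond the scatter). No evidence on hand bears on this result.

Open, on these data alone, is whether a longer chain, or an amine on the chain, would read with compound 2 or with compound 4.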